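Hydrazone aryl swap within a shared urea series

A few compounds are considered here, and "the series" means these few. Any claim that something is new, unique, unknown or untested is made for them only; others in the source may bear on it.

Measured compounds:
compound 1 `CN(C)CCn1cnnc1-c1cc(Oc2ccc(NC(=O)N/N=C/c3cccc(Br)c3)cc2F)ccn1` – 4230 nM
compound 2 `CN(C)CCn1cnnc1-c1cc(Oc2ccc(NC(=O)N/N=C/c3cc(Br)c(O)c(Br)c3)cc2F)ccn1` – "not determined" (no result reported)
compound 3 `COc1ccc(/C=N/NC(=O)Nc2ccc(Oc3ccnc(-c4nncn4CCN(C)C)c3)c(F)c2)cc1O` – "not determined" (no result reported)

Among the compounds with values here, in an ADME assay on WI-38 cells (Homo sapiens) for cytotoxicity, read by MTT assay, with a stated time of 72 h (on this read-out lower numbers stand for stronger inhibition and higher numbers for weaker inhibition), compound 1 gives 4230 nM and is the only compound with a number; for compound 2 and compound 3 no result is reported, so compound 1 stands alone and no comparison is possible.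

Compound 4 `CN(C)CCn1cnnc1-c1cc(Oc2ccc(NC(=O)N/N=C/c3c(Cl)cccc3Cl)cc2F)ccn1` is not yet measured. It differs from compound 1 as follows: 2,6-dichlorophenyl in place of 3-bromophenyl on a carbon with a double bond to nitrogen. Within the data shown here, with no measured step, the change is expected to give at most a small shift in this assay, in either direction, likely within the scatter. The expected step from compound 1 to compound 4 is a 1.2-fold higher number from compound 1 to compound 4 (0.07 log units; within the scatter). Compound 4 is estimated at 5000 nM, with a range from 1500 nM to 15000 nM.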

Compound 4, half-maximal inhibitory concentration: 3320 nM
Estimate against measurement, compound 4: 1.5-fold (0.18 log units) above; the measured number falls inside the stated range.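

At the aryl group on a carbon with a double bond to nitrogen, this assay now gives a first readable step. Replacing 3-bromophenyl with 2,6-dichlorophenyl gives a 1.3-fold lower number from compound 1 to compound 4 (0.11 log units; within the scatter) and leaves the two compounds indistinguishable on this read-out. No measured property bears on this result.

Steps involving compound 2 and compound 3 cannot be read. On these data alone, whether a pyridine ring at this position, or a phenyl bearing an amine or a carboxylic acid, would give a step beyond the scatter remains open.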